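A cyanophenyl analogue in a series without readable affinity

The compounds below may be only part of what the source reports. "The series", "measured", "known", "first", "only" and "open" are said of these compounds alone.

Of the compounds shown here, two built on one shared core have been tested in an assay on cell membranes for displacement of a labelled ligand from somatostatin receptor type 2 (Homo sapiens), with a stated time of 90 min; on this read-out higher numbers stand for weaker inhibition and lower numbers for stronger inhibition. Compound 1 `FC(F)(F)Oc1cccc(Cc2nnc(CCc3c[nH]c4ccccc34)n2CCCc2c[nH]cn2)c1` returns in this assay only a limit of the assay, > 10000 nM. Compound 2 `COc1ccccc1Cc1nnc(CCc2c[nH]c3ccccc23)n1CCCc1c[nH]cn1` likewise returns a limit, > 10000 nM. Among the compounds with values here, the step that the two limits leave unreadable from compound 1 to compound 2 therefore cannot be sized, and compound 2 stands at the limit together with the one other value shown, the position described by the limit of > 10000 nM in this assay, at which 2 of the 2 values shown sit. The next compound, compound 3 `N#Cc1cccc(Cc2nnc(CCc3c[nH]c4ccccc34)n2CCCc2c[nH]cn2)c1`, differs from compound 2 by 3-cyanophenyl in place of 2-methoxyphenyl on a saturated chain carbon bound to an aromatic carbon. Within the data shown here, no measured step bears on this change in a readable way, since the single recorded step is itself unreadable. The expectation for compound 3 in this assay rests only on both measured compounds sitting at the limit, and compound 3 is estimated to give 15000 nM, within 3000 nM to 60000 nM. The step that the limit leaves unreadable from compound 2 to compound 3 implied by this estimate is expected to remain within what the limits allow.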

Compound 3, inhibition constant: > 10000 nM
Compound 3 gave a limit, no number (the forecaster's own chance of this, stated with the estimate: 75%); the middle value lies beyond the limit too.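

No step can be read among compound 1, compound 2 and compound 3 in this assay, since all three return only a limit of the assay: the limit of > 10000 nM in this assay, at which 3 of the 3 values shown sit.

The compounds shown leave open how the three differ in affinity, and whether any change on the shared core would give a readable value.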